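A few compounds are considered here, and "the series" means these few. Any claim that something is new, unique, unknown or untested is made for them only; others in the source may bear on it.

Measured so far:

Compound 1 `CN(CCCNS(=O)(=O)c1cc(C(F)(F)F)cc(C(F)(F)F)c1)Cc1ccccc1`: 39000 nM
Compound 2 `CC(C)(C)c1ccc(CNCCNS(=O)(=O)c2cc(C(F)(F)F)cc(C(F)(F)F)c2)cc1`: 8800 nM

In a functional assay on BXPC-3 cells (Homo sapiens) for inhibition, read by MTT assay, with a stated time of 72 h (on this read-out higher numbers stand for weaker inhibition of growth and lower numbers for stronger inhibition of growth), compound 1 gives 39000 nM, the higher of the two numbers measured. Compound 2 gives 8800 nM in this assay, and the gap between these two values lies beyond the usual scatter, so compound 1 is the weaker of the pair. Compound 2 differs from compound 1 in more than one place, so it does not by itself show the size of any single change.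

Compound 3 `O=S(=O)(NCCCNCc1ccc(Cl)cc1)c1cc(C(F)(F)F)cc(C(F)(F)F)c1` has not yet been measured. It differs from compound 1 in one place: (4-chlorobenzyl)amino in place of benzyl(methyl)amino on a saturated chain carbon, three bonds along the chain from a sulfonamide nitrogen. Among the compounds with values here, no measured pair shows this exact change, so its effect in this assay can only be guessed from the two values at hand. Compound 1 sits at the weak end of what has been measured, which leaves room for a lower number. The step from compound 1 to compound 3 is expected to be a 2.6-fold lower number from compound 1 to compound 3 (0.41 log units; beyond the scatter), toward stronger inhibition but with wide uncertainty. For compound 3 the estimate in this assay is 15000 nM, with a likely range from 5000 nM to 45000 nM.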

Compound 3, concentration for 50% growth inhibition: 1600 nM
Compound 3: middle estimate off by 9.4-fold (0.97 log units), on the high side; measured number below the stated range.
By their numbers in this assay, from the lowest: compound 3; then compound 2; then compound 1.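

In this assay, putting (4-chlorobenzyl)amino in place of benzyl(methyl)amino on a saturated chain carbon, three bonds along the chain from a sulfonamide nitrogen, gives a 24-fold lower number from compound 1 to compound 3 (1.39 log units; beyond the scatter) and so moves the read-out toward stronger inhibition of growth. Within the data shown here, this is the first step that can be read as a single-place change, and its large size shows that the number responds strongly to what sits at this position, even though the heavy-atom count of 9 stays the same. The change is really two edits in one group, since the amine nitrogen trades its methyl for a hydrogen, adding a hydrogen-bond donor, while the aromatic ring gains a chlorine, and nothing at hand explains why the number moves.

As far as these compounds go, it remains open how much of the step belongs to each edit, which plain benzylamino or (4-chlorobenzyl)(methyl)amino at this position would help to separate. Also open, from the compounds shown here alone, is how a bromine or a methoxy group in place of the chlorine, or a longer chain, would shift the number.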